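Replacing pyridin-3-yl with 1H-indazol-6-yl

A few compounds are considered here, and "the series" means these few. Any claim that something is new, unique, unknown or untested is made for them only; others in the source may bear on it.

- Compound 1 `O=C(Nc1ccc(-c2cscn2)cc1)C1CCCN(Cc2ccc(Cl)c(Cl)c2)C1`: 1730 nM
- Compound 2 `O=C(Nc1ccc(-c2cscn2)cc1)C1CCCN(Cc2cccnc2)C1`: > 20000 nM

In a functional assay on A-375 cells (Homo sapiens) for antiproliferative activity (a higher number here means a weaker inhibitor, a lower number a stronger inhibitor), compound 1 gives 1730 nM. Compound 2 stands at > 20000 nM, which is a limit of the assay and not a number. Among the compounds with values here, only one measured step bears on the next change, and it is large: an at least 11-fold higher number from compound 1 to compound 2 (1.06 log units; beyond the scatter). It falls at the same place, on a saturated chain carbon bound to an amine nitrogen in a ring. Compound 3 `O=C(Nc1ccc(-c2cscn2)cc1)C1CCCN(Cc2ccc3cn[nH]c3c2)C1` alters that place again: 1H-indazol-6-yl in place of pyridin-3-yl on a saturated chain carbon bound to an amine nitrogen in a ring. Compound 1 keeps a lower number than the limit of compound 2, so the group here matters, but a single step cannot fix the size of the next one. A moderate move to a lower number is expected, and compound 3 may yet remain at the limit. The estimate amounts to an expected at least 2.5-fold lower number from compound 2 to compound 3 (0.39 log units; beyond the scatter). For compound 3 the expected value is 8000 nM, with an estimated range of 2500 nM to 20000 nM.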

Compound 3, half-maximal inhibitory concentration: > 20000 nM
Compound 3 gave a limit, no number; the forecaster's own chance of this, stated with the estimate: 30%; middle value at least 2.5-fold (0.39 log units) from the limit.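

In this assay, the change to 1H-indazol-6-yl gives an at least 11-fold higher number from compound 1 to compound 3 (1.06 log units; beyond the scatter), so a second group at this place, on a saturated chain carbon bound to an amine nitrogen in a ring, also falls far short of 3,4-dichlorophenyl. Of the three groups shown, only 3,4-dichlorophenyl gives a number and not a limit; the added five-membered aromatic ring and hydrogen-bond donor of 1H-indazol-6-yl do not bring a number back. The step from compound 2 to compound 3 cannot be read because both values are limits: the limit of > 20000 nM in this assay, at which 2 of the 3 values shown sit.

On these data alone, it remains open whether a plain phenyl, or a phenyl carrying a single chlorine, would keep a number at this place. As far as these compounds go, how pyridin-3-yl and 1H-indazol-6-yl rank against each other also remains open.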